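The source may report more compounds than this note shows. Statements on the series, on what has been measured and on what is new or still open speak of the compounds shown alone.

In an assay for binding affinity to leukotriene B4 receptor 1 (Homo sapiens) (on this read-out lower numbers stand for stronger inhibition and higher numbers for weaker inhibition), compound 3 `COc1ccc(CCCCCCCCOc2ccc(CSc3cccc(C(=O)O)c3)nc2/C=C/C(=O)O)cc1` gives 80 nM, the lowest of the three numbers recorded. Compound 1 `CCCCCCCCCCCCOc1ccc(C[S+]([O-])c2ccc(C(=O)O)cc2)nc1/C=C/C(=O)O` gives 252 nM, and compound 2 `CCCCCCCCCCCCOc1ccc(C[S+]([O-])c2ccccc2C(=O)O)nc1/C=C/C(=O)O` gives 478 nM. Compound 4 `COc1ccc(CCCCCCCCOc2ccc(CSc3ccccc3)nc2/C=C/C(=O)O)cc1` differs from compound 3 by hydrogen in place of carboxy on an aromatic carbon. Going by the values given here, the single measured step, a 1.9-fold higher number from compound 1 to compound 2 (0.28 log units; within the scatter), only moves the carboxy to another position on that ring and keeps it, so it offers no direct guide to what removing the group does. Every measured compound carries this carboxy, so nothing recorded tells how its loss acts. The loss is nonetheless expected to weaken binding by a moderate step, a 3.1-fold higher number from compound 3 to compound 4 (0.49 log units; beyond the scatter), as a cautious guess rather than a pattern. Compound 4 is therefore estimated at 250 nM, within a range from 80 nM to 800 nM.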

Compound 4, inhibition constant: 74 nM
The estimate for compound 4 lay 3.4-fold (0.53 log units) above the measured number; measured number below the stated range.
By their numbers in this assay, from the lowest: compounds 4 and 3 (each within the scatter of the next); then compounds 1 and 2 (each within the scatter of the next).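

Hydrogen in place of carboxy gives a 1.1-fold lower number from compound 3 to compound 4 (0.03 log units; within the scatter) in this assay and so no change beyond the scatter. Going by these compounds alone, for this pair, then, the carboxy on this ring is not needed to keep the number where it stands, which the earlier compounds, all carrying the group, could not show. No measured evidence here explains this result. Going by these compounds, whether an amine or a nitrile on the same aromatic carbon would also leave the number unmoved remains open. So does whether compound 1 or compound 2 would tolerate losing the carboxy.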